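The compounds below may be only part of what the source reports. "The series", "measured", "known", "first", "only" and "open" are said of these compounds alone.

Among the compounds with values here, compound 1, with the structure `O=C(CCCSc1nc2cc(Cl)ccc2o1)N1CCCC1`, is one of three compounds measured in an ADME assay on microsomes from liver (Mus musculus) for metabolic stability, read by LC-MS, using NADPH, with a stated time of 45 min, tested at 0.5 uM; a higher number here means faster removal of the compound, a lower number slower removal. Compound 1 gives 125 mL/min/g, the highest of the three numbers. Compound 2, `CCN(CC)C(=O)CCSc1nc2cc(Cl)ccc2o1`, gives 108 mL/min/g in this assay, a value that sits within the scatter of compound 1. Compound 3, `O=C(CCSc1nc2ncccc2o1)N1CCCC1`, gives 18.6 mL/min/g in this assay, and its gap to compound 1 lies beyond the scatter; these two differ in more than one place, so nothing about any single change can be drawn from that pair.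

Compound 4, `O=S1(=O)CCCN1CCCSc1nc2cc(Cl)ccc2o1`, has not yet been measured in this assay. Its relation to compound 1 is a single exchange: a group of 7 heavy atoms (3 carbon, 1 nitrogen, 2 oxygen, 1 sulfur; one five-membered non-aromatic ring with 2 hetero atoms) in place of a group of 7 heavy atoms (5 carbon, 1 nitrogen, 1 oxygen; one five-membered non-aromatic ring with 1 hetero atom), on a saturated chain carbon, three bonds along the chain from a sulfur. Within the data shown here, no pair among the measured compounds isolates this change, so there is no measured step to lean on. For compound 4 the expectation in this assay is a step of a 1.5-fold lower number from compound 1 to compound 4 (0.17 log units; within the scatter), a size that does not clearly pass beyond the scatter. Compound 4 is therefore estimated at 85 mL/min/g, with a range from 40 mL/min/g to 180 mL/min/g.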

Compound 4, intrinsic clearance in a liver preparation (reported as CLH), per the amount of preparation that the assay uses: 115 mL/min/g
Compound 4: middle estimate off by 1.4-fold (0.13 log units), on the low side; the measured number falls inside the stated range.
By their numbers in this assay, from the lowest: compound 3; then compounds 2, 4 and 1 (each within the scatter of the next).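

Within the data shown here, this is the first measured step at this place, on a saturated chain carbon, three bonds along the chain from a sulfur. In this assay, putting the five-membered ring with 2 hetero atoms in place of the (pyrrolidin-1-yl)carbonyl group gives a 1.1-fold lower number from compound 1 to compound 4 (0.04 log units; within the scatter), so compound 1 and compound 4 cannot be told apart. The two groups have the same number of heavy atoms but differ in their atoms and ring, and that difference leaves no measurable mark on this read-out for this pair, although nothing measured here explains the result.

The compounds shown leave open whether a group of another kind at this place, such as a carboxylic acid or an amine, would move the number beyond the scatter. They also leave open whether this same exchange would give a similar result on a different core or a shorter chain.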